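A few compounds are considered here, and "the series" means these few. Any claim that something is new, unique, unknown or untested is made for them only; others in the source may bear on it.

Measured so far in a functional assay on SW480 cells (Homo sapiens) for antiproliferative activity, read by MTT assay, with a stated time of 48 h; on this read-out higher numbers stand for weaker inhibition and lower numbers for stronger inhibition:
- compound 1 `CCCCCC(CCO)n1cnc2c(NC)ncnc21`: > 50000 nM
- compound 2 `CCCCCC(CCO)n1cnc2c(N)nc(Cl)nc21`: > 50000 nM

Neither entry is a number: each value is a limit of the read-out. Compound 1 sits at the limit of > 50000 nM in this assay, at which 2 of the 2 values shown sit. Among the measured compounds shown here, its place therefore cannot be told more closely than that limit, and no measured pair differs in one place only.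

Next in line is compound 3 `CCCCCC(CCO)n1cnc2cncnc21`. Compared with compound 1, it has hydrogen in place of methylamino on an aromatic carbon.

In this assay, no step beyond the usual scatter is expected, and no direction is favoured. The expectation rests on compound 1 with > 50000 nM, which is a limit. Compound 3 is therefore expected to remain at the limit of the read-out, with a measurable number the less likely result. The expected size of the change is a step that the limit leaves unreadable from compound 1 to compound 3. For compound 3 the estimated value is 60000 nM, with an expected range of 25000 nM to 150000 nM.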

Compound 3, half-maximal inhibitory concentration: > 50000 nM
Compound 3 ended at the assay's limit; the forecaster's own chance of this, stated with the estimate: 85%; the middle value does not contradict the limit.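

In this assay no step can be read from compound 1 to compound 3, because both entries are limits and not numbers: the limit of > 50000 nM in this assay, at which 3 of the 3 values shown sit.

The compounds shown leave open what hydrogen in place of methylamino on an aromatic carbon does to the read-out, and whether any change to the shared core gives a measurable value in this assay.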